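A Chloro Substituent Added to a Series Sitting at the Limit

The compounds below may be only part of what the source reports. "The series", "measured", "known", "first", "only" and "open" are said of these compounds alone.

Compound 2 `Cc1ccc(Nc2nc(C)c(C(=O)/C=C/c3ccccc3)s2)cc1` is one of three compounds tested in a functional assay on BGC-823 cells (Homo sapiens) for cytotoxicity, read by MTT assay; a higher number here means a weaker inhibitor, a lower number a stronger inhibitor. In this assay compound 2 gives > 25000 nM, which is a limit of the assay rather than a number. Compound 3 `Cc1ccccc1Nc1nc(C)c(C(=O)/C=C/c2ccccc2)s1` likewise reaches only a limit in this assay, > 25000 nM. Compound 1 `Cc1ccccc1Nc1nc(C)c(C(=O)/C=C/c2ccccc2Cl)s1` also gives a limit in this assay, > 25000 nM. the limit of > 25000 nM in this assay, at which 3 of the 3 values shown sit. The step that the two limits leave unreadable from compound 2 to compound 3 and the step that the two limits leave unreadable from compound 1 to compound 3 are therefore both unreadable in size. Compound 4 `Cc1ccc(Nc2nc(C)c(C(=O)/C=C/c3ccccc3Cl)s2)cc1` differs from compound 2 in one place: chloro in place of hydrogen on an aromatic carbon. The step from compound 1 to compound 3 covers the reverse of this change, but its size cannot be read from two limits. For compound 4 the expected outcome in this assay is another limit, estimated at 35000 nM (from 10000 nM to 120000 nM), an expected step that the limit leaves unreadable from compound 2 to compound 4.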

Compound 4, half-maximal inhibitory concentration: > 25000 nM
Compound 4: no number, only a limit (the forecaster's own chance of this, stated with the estimate: 85%); the middle value is on the limit's open side.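

In this assay compound 4 also gives only a limit, > 25000 nM, so its steps from compound 2 and from compound 1 cannot be read: the limit of > 25000 nM in this assay, at which 4 of the 4 values shown sit. Whether chloro changes the activity of these compounds at all stays open.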